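Going from methoxy to ethoxy

The compounds below may be only part of what the source reports. "The series", "measured", "known", "first", "only" and "open" are said of these compounds alone.

Measured so far in a functional assay on the whole organism (stomach) for inhibition, with Rattus norvegicus as the target (a higher number here means that more compound is needed for the effect, a lower number that less compound is needed), are two compounds:
compound 1 `CCOc1cc(OC)ccc1C[S+]([O-])c1ncccc1C(=O)Nc1ccncc1` gives 19 mg/kg
compound 2 `COc1ccc(C[S+]([O-])c2ncccc2C(=O)Nc2ccncc2)c(OC)c1` gives 4.2 mg/kg

Compound 1 has the higher of the two numbers, so more of it is needed. Compound 3 `CCOc1ccc(C[S+]([O-])c2ncccc2C(=O)Nc2ccncc2)c(OCC)c1` differs from it by methyl in place of hydrogen on a saturated chain carbon bound to an oxygen on an aromatic ring with methyl in place of hydrogen, turning methoxy into ethoxy. For the measured compounds named here, the only measured step that bears on this is a 4.5-fold lower number from compound 1 to compound 2 (0.66 log units; beyond the scatter) which is the reverse kind of change, made on the other such chain. A rise of similar or smaller size is therefore expected, though one step is thin evidence. The expected move is a 1.8-fold higher number from compound 1 to compound 3 (0.27 log units; within the scatter) in this assay overall. Compound 3 is estimated at 35 mg/kg with 11 mg/kg to 100 mg/kg as the expected range.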

Compound 3, dose for half-maximal effect: 11.2 mg/kg
Compound 3: the middle estimate sits 3.1-fold (0.49 log units) above what was measured, within the range that was stated.
By their numbers in this assay, from the lowest: compound 2; then compounds 3 and 1 (each within the scatter of the next).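

In this assay, turning methoxy into ethoxy at this place gives a 1.7-fold lower number from compound 1 to compound 3 (0.23 log units; within the scatter), so this chain takes the extra methyl without a shift beyond the usual scatter. The other chain reads differently, with a 4.5-fold lower number from compound 1 to compound 2 (0.66 log units; beyond the scatter), so the same small difference does not count equally at the two places. Nothing measured here explains why the two places differ. Still open, on these data alone, is how a longer chain such as propoxy would read at this place. As far as these compounds go, a chain ending in an amine is equally open.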